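The source may hold more compounds than are shown below. What is called first, only, known or untested is meant among the compounds shown, and "the series" means these compounds.

Working notes on the series. Compound 1 `CN(C)CCn1cnnc1-c1cc(Oc2ccc(NC(=O)N/N=C/c3cccc(Br)c3)cc2F)ccn1`, compound 2 `CN(C)CCn1cnnc1-c1cc(Oc2ccc(NC(=O)N/N=C/c3cccc(O)c3)cc2F)ccn1` and compound 3 `CN(C)CCn1cnnc1-c1cc(Oc2ccc(NC(=O)N/N=C/c3ccc(O)c(F)c3)cc2F)ccn1` share one core and differ only in the aryl group on a carbon with a double bond to nitrogen. In an ADME assay on WI-38 cells (Homo sapiens) for cytotoxicity, read by MTT assay, with a stated time of 72 h (a lower number here means a stronger inhibitor, a higher number a weaker inhibitor), compound 1 gives 4230 nM. In this assay compound 2 gives "not determined" (no result reported). In this assay compound 3 gives "not determined" (no result reported). For the measured compounds named here, compound 3 thus stands without a number, and the single reading is that of compound 1. Compound 4 `CN(C)CCn1cnnc1-c1cc(Oc2ccc(NC(=O)N/N=C/c3c(O)ccc4ccccc34)cc2F)ccn1` differs from compound 3 by 2-hydroxynaphthalen-1-yl in place of 3-fluoro-4-hydroxyphenyl on a carbon with a double bond to nitrogen. Going by the values given here, no step between measured compounds is available to size this change; the expectation for compound 4 in this assay rests on compound 1, with a step no larger than the scatter in either direction. Compound 4 is expected to give about 4000 nM in this assay, estimated within 1200 nM to 15000 nM.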

Compound 4, half-maximal inhibitory concentration: 3250 nM
Estimate against measurement, compound 4: 1.2-fold (0.09 log units) above; the measured number falls inside the stated range.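

In this assay, the first step readable at this position gives a 1.3-fold lower number from compound 1 to compound 4 (0.11 log units; within the scatter). On a carbon with a double bond to nitrogen, exchanging 3-bromophenyl for 2-hydroxynaphthalen-1-yl, which brings 2 six-membered aromatic rings of carbon only, thus leaves the reading within the scatter. Nothing at hand bears on why this exchange has so small a step.

Steps to compound 2 and compound 3 cannot be read. On these data alone, whether an amine or a carboxylic acid on the aryl group would take the number beyond the scatter remains open.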